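Urea series: solubility and the substituent ortho to a large group

The compounds below may be only part of what the source reports. "The series", "measured", "known", "first", "only" and "open" are said of these compounds alone.

Measured so far in a physicochemical assay for solubility, at pH 7.4; a higher number here means a more soluble compound, a lower number a less soluble compound:
compound 1, `Cc1cc(NC(=O)Nc2ccccc2F)c2ccccc2n1`, gives 3800 nM
compound 2, `CSc1ccccc1NC(=O)Nc1cc(C)nc2ccccc12`, gives 21000 nM
compound 3, `Cc1cc(NC(=O)Nc2ccccc2OC(F)(F)F)c2ccccc2n1`, gives 4600 nM

Compound 3 stands second highest of the three numbers. The step of a 1.2-fold higher number from compound 1 to compound 3 (0.08 log units; within the scatter) lies within the scatter, so compound 1 and compound 3 cannot be told apart on this assay; the step of a 4.6-fold lower number from compound 2 to compound 3 (0.66 log units; beyond the scatter) is modest and beyond the scatter, and compound 2 is the furthest of the three from compound 3.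

Compound 4, `Cc1cc(NC(=O)Nc2ccccc2[N+](=O)[O-])c2ccccc2n1`, differs from compound 3 in one place: nitro in place of trifluoromethoxy on an aromatic carbon.

Among the compounds with values here, two measured steps bear on this, both exchanges of the group on the same aromatic carbon ortho to a large group. Exchanging fluoro for trifluoromethoxy moved nothing beyond the scatter, a 1.2-fold higher number from compound 1 to compound 3 (0.08 log units; within the scatter). Exchanging methylsulfanyl for trifluoromethoxy gave a 4.6-fold lower number from compound 2 to compound 3 (0.66 log units; beyond the scatter). Within the data shown here, no nitro analogue has been measured, so the step for compound 4 is expected to be a 1.2-fold higher number from compound 3 to compound 4 (0.08 log units; within the scatter), within the scatter or at most modest, with no firm direction. Compound 4 is therefore estimated at 5500 nM, in the range 2000 nM to 15000 nM.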

Compound 4, solubility: 200 nM
Compound 4: the middle estimate sits 28-fold (1.44 log units) above what was measured; measured number below the stated range.
By their numbers in this assay, from the lowest: compound 4; then compounds 1 and 3 (each within the scatter of the next); then compound 2.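

In this assay the aromatic carbon ortho to a large group proves far more sensitive to the choice of group than the exchanges among fluoro, methylsulfanyl and trifluoromethoxy had shown. Nitro in place of trifluoromethoxy gives (a 23-fold lower number from compound 3 to compound 4 (1.36 log units; beyond the scatter)), nitro in place of fluoro gives (a 19-fold lower number from compound 1 to compound 4 (1.28 log units; beyond the scatter)) and nitro in place of methylsulfanyl gives (a 110-fold lower number from compound 2 to compound 4 (2.02 log units; beyond the scatter)), so all three steps are large and compound 4 stands clearly apart as the lowest of the set. Nothing available accounts for this drop.

On these data alone, it remains open whether the drop is particular to nitro or would also appear with a nitrile, an amine or a carboxylic acid on the same carbon. As far as these compounds go, all four compounds share one core, so whether the nitro step carries over to a different core also remains open.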